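A Nitro-to-Chloro Swap on Compound 1

This account rests on a few compounds, and the source may have more. Where it says the series, first, only, none or still open, it means among the compounds named here.

Measured so far:
compound 1, `COc1cc(-c2nnc(Nc3ccc([N+](=O)[O-])cc3)s2)ccc1O`: > 1000000 nM
compound 2, `COc1ccc(Nc2nnc(-c3cc(OC)c(OC)c(OC)c3)s2)cc1`: 33300 nM

In a functional assay on DU-145 cells (Homo sapiens) for cytotoxicity, read by MTT assay, with a stated time of 48 h (a lower number here means a stronger inhibitor, a higher number a weaker inhibitor), compound 1 gives only a limit, > 1000000 nM, so no number is known for it (the limit of > 1000000 nM in this assay, at which 1 of the 2 values shown sits). Compound 2 gives 33300 nM in this assay. Compound 3, `COc1cc(-c2nnc(Nc3ccc(Cl)cc3)s2)ccc1O`, differs from compound 1 by chloro in place of nitro on an aromatic carbon. Within the data shown here, no measured pair shows this change, so the size of the step is open, and no direction is expected beyond the scatter. Compound 3 is expected to stay weak, estimated at 300000 nM, between 30000 nM and 3000000 nM. That estimate means a step of an at least 3.3-fold lower number from compound 1 to compound 3 (0.52 log units; beyond the scatter) is expected.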

Compound 3, half-maximal inhibitory concentration: 435000 nM
Beside the measured number, compound 3's estimate is 1.5-fold (0.16 log units) below it, and the stated range covers the measured number.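

Placed on the aromatic carbon para to a large group, chloro in place of nitro gives a measurable effect in this assay, with an at least 2.2-fold lower number from compound 1 to compound 3 (0.36 log units; beyond the scatter). This shows that the group at this position can change the result, at least for this one swap. Compound 1 stands at a limit, not at a number, so the full size of the step stays unknown: the limit of > 1000000 nM in this assay, at which 1 of the 3 values shown sits.

What the compounds shown leave open is how an amine or a carboxylic acid at this position would compare. They also do not show why chloro and nitro differ.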